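Swapping the sugar for a protected diol on compound 2

The source may report more compounds than this note shows. Statements on the series, on what has been measured and on what is new or still open speak of the compounds shown alone.

Of the compounds shown here, three of one shared core have been measured in a functional assay on MCF7 cells (Homo sapiens) for cytotoxicity, read by MTT assay, with a stated time of 72 h; a higher number here means a weaker inhibitor, a lower number a stronger inhibitor. Compound 1 `CN1CCN(CCCCCCn2c3c(c4ccccc42)C(=O)c2c[n+]([O-])c4ccccc4c2C3=O)CC1` gives 400 nM, compound 3 `CN(C)CCCCn1c2c(c3ccccc31)C(=O)c1c[n+]([O-])c3ccccc3c1C2=O` gives 220 nM, and compound 2 `O=C1c2c[n+]([O-])c3ccccc3c2C(=O)c2c1c1ccccc1n2Cc1cn([C@H]2C[C@H](O)[C@@H](CO)O2)nn1` gives 530 nM. Compound 2 and compound 1 sit within the scatter of each other, whereas compound 3 sits beyond the scatter below compound 2. Within the data shown here, the one single-point step among them, a 1.8-fold lower number from compound 1 to compound 3 (0.26 log units; within the scatter), concerns a different chain and stays within the scatter.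

Compound 4 `CC1(C)OC[C@@H](Cn2cc(Cn3c4c(c5ccccc53)C(=O)c3c[n+]([O-])c5ccccc5c3C4=O)nn2)O1` is the next compound, differing from compound 2 in one place: (2,2-dimethyl-1,3-dioxolan-4-yl)methyl in place of 4-hydroxy-5-(hydroxymethyl)oxolan-2-yl on an aromatic nitrogen. Among the measured compounds shown here, no measured step touches this group, and the only step available, from compound 1 to compound 3, lies within the scatter, so there is no ground to expect a step in this assay beyond the scatter in either direction. Compound 4 is therefore expected to give about 450 nM, between 200 nM and 1200 nM, a step of a 1.2-fold lower number from compound 2 to compound 4 (0.07 log units; within the scatter) from compound 2, which is an estimate only.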

Compound 4, half-maximal inhibitory concentration: > 1000 nM
Compound 4: only a limit was reported; the forecaster's own chance of this, stated with the estimate: 5%; middle value at least 2.2-fold (0.34 log units) away from the limit.
By their numbers in this assay, from the lowest: compounds 3, 1 and 2 (each within the scatter of the next, the first and the last beyond it). At a limit, above all of these: compound 4.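

In this assay compound 4 gives > 1000 nM, which is a limit and not a number. This is the first change shown on the aromatic nitrogen of the five-membered aromatic ring with 3 nitrogen, and an at least 1.8-fold higher number from compound 2 to compound 4 (0.27 log units; that floor lies within the scatter) shows no gain from this exchange, although the true size of the step remains unknown and may or may not lie beyond the scatter. The exchange replaces a group with 2 hydrogen-bond donors and 3 defined stereocentres by one with 0 hydrogen-bond donors and 1 defined stereocentre, and one pair of compounds cannot show which of these differences matters.

The compounds shown leave open whether a 2,3-dihydroxypropyl group on this aromatic nitrogen, which restores free hydroxyl groups without the oxolane ring, would behave like compound 2 or compound 4. They also leave open how a chain ending in a dimethylamino group would read at this same place.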